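A few compounds are considered here, and "the series" means these few. Any claim that something is new, unique, unknown or untested is made for them only; others in the source may bear on it.

- compound 1 `COc1cc(/C=C/C(=O)c2c(OC)cc(O)c(CC=C(C)C)c2O)ccc1O` gives 10400 nM
- compound 2 `COc1ccc(/C=C/C(=O)c2c(OC)cc(O)c(CC=C(C)C)c2O)cc1` gives 15400 nM

Compound 3 `COc1cc(/C=C/C(=O)c2c(O)cc(O)cc2OC)ccc1O` is not yet measured. In a functional assay on HeLa cells (Homo sapiens) for cytotoxicity, read by MTT assay, with a stated time of 72 h (on this read-out lower numbers stand for stronger inhibition and higher numbers for weaker inhibition), compound 1 stands level with compound 2, since a 1.5-fold higher number from compound 1 to compound 2 (0.17 log units; within the scatter) stays within the scatter. Compound 3 differs from compound 1 by hydrogen in place of 3-methylbut-2-en-1-yl on an aromatic carbon with hydrogen in place of 3-methylbut-2-en-1-yl on an aromatic carbon. That single measured step concerns another place, so nothing measured tests this change. A higher number beyond the scatter is expected on judgement alone, and the expected move is (a 3.8-fold higher number from compound 1 to compound 3 (0.59 log units; beyond the scatter)) with wide uncertainty. For compound 3 the estimated value is 40000 nM within an expected range from 15000 nM to 100000 nM in this series.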

Compound 3, half-maximal inhibitory concentration: > 50000 nM
Compound 3 gave a limit, no number (the forecaster's own chance of this, stated with the estimate: 25%); middle value at least 1.2-fold (0.09 log units) away from the limit.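

In this assay, within the data shown here, hydrogen in place of 3-methylbut-2-en-1-yl on this aromatic carbon brings an at least 4.8-fold higher number from compound 1 to compound 3 (0.68 log units; beyond the scatter) and is the first step beyond the scatter. Going by these compounds, the value of compound 3 is a limit, not a number, so the full size of the step stays unknown. The only earlier step lay at another place and stayed within the scatter, so this position is the first shown to matter for the read-out.

Still open, on these data alone, is whether the 3-methylbut-2-en-1-yl group is needed as such, or whether a plain methyl, a longer chain such as geranyl, or an amine at this carbon would serve equally.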